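Swapping the amide aryl group on a quinolone core

The source may report more compounds than this note shows. Statements on the series, on what has been measured and on what is new or still open speak of the compounds shown alone.

Two compounds share one core and differ only in the group carried on the amide-type nitrogen. Compound 1 `CCn1cc(-c2nc3ccc([N+](=O)[O-])cc3o2)c(=O)c2cc(F)c(N3CCNC(C)C3)c(F)c21` bears a nitrobenzoxazole in place of the amide and in a functional assay on KB cells (Homo sapiens) for cytotoxicity, read by MTT assay (on this read-out lower numbers stand for stronger inhibition and higher numbers for weaker inhibition), gives 900 nM. Compound 2 `CCn1cc(C(=O)Nc2ccc(Cl)cn2)c(=O)c2cc(F)c(N3CCNC(C)C3)c(F)c21` carries a 5-chloropyridin-2-yl amide and in this assay gives 1600 nM, the higher of the two numbers, though compound 1 lies within the usual scatter of it, so the two cannot be told apart. Compound 3 `CCn1cc(C(=O)Nc2cc([N+](=O)[O-])ccc2F)c(=O)c2cc(F)c(N3CCNC(C)C3)c(F)c21` is the next step: 2-fluoro-5-nitrophenyl in place of 5-chloropyridin-2-yl on an amide-type nitrogen. Among the measured compounds shown here, no measured pair shows what this change does, so the expectation rests on the two numbers alone. The step from compound 2 to compound 3 is expected to be a 1.1-fold lower number from compound 2 to compound 3 (0.03 log units; within the scatter), that is, nothing beyond the scatter. Compound 3 is therefore estimated at 1500 nM, with a range from 500 nM to 5000 nM.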

Compound 3, half-maximal inhibitory concentration: 3200 nM
Beside the measured number, compound 3's estimate is 2.1-fold (0.33 log units) below it, within the range that was stated.
By their numbers in this assay, from the lowest: compounds 1, 2 and 3 (each within the scatter of the next, the first and the last beyond it).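

In this assay, putting 2-fluoro-5-nitrophenyl in place of 5-chloropyridin-2-yl on the amide-type nitrogen gives a 2.0-fold higher number from compound 2 to compound 3 (0.30 log units; within the scatter) and so shows that this position accepts a carbon-only aromatic ring in place of one holding a hetero atom, with no step beyond the scatter. Among the compounds shown here, this is the first pair that differs only in this group, but a single pair sets no trend for the position. Nothing measured here ties the result to a cause or to any feature of either group.

Still open, going by these compounds, is what a plain phenyl, or a phenyl carrying only the fluorine or only the nitro group, would give on this nitrogen, so the share of each group in compound 3 cannot be told. Also open, on these data alone, is whether a non-aromatic group such as cyclohexyl or a short alkyl chain would move the number beyond the scatter.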